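The source may hold more compounds than are shown below. What is called first, only, known or untested is meant among the compounds shown, and "the series" means these compounds.

Compound 1 `COc1ccc(-c2cn3cc(C4=CCN(C(=O)C5CCCCC5)CC4)ccc3n2)cc1OC` gives 7310 nM in a functional assay on A549 cells (Homo sapiens) for antiproliferative activity, read by MTT assay, with a stated time of 48 h; on this read-out lower numbers stand for stronger inhibition and higher numbers for weaker inhibition. Compound 2 `COc1ccc(-c2cn3cc(C4=CCN(S(=O)(=O)c5ccccc5)CC4)ccc3n2)cc1OC` gives 7660 nM.

Going by the values given here, on these two numbers compound 1 stands lowest, with compound 2 the nearest, and the single step of a 1.0-fold higher number from compound 1 to compound 2 (0.02 log units; within the scatter) shows that swapping the group on the ring amine nitrogen left the read-out unchanged. Compound 3 `COc1ccc(-c2cn3cc(C4=CCN(C(=O)c5cccc(C(F)(F)F)c5)CC4)ccc3n2)cc1OC` is the next variation: 3-(trifluoromethyl)phenyl in place of cyclohexyl on a carbonyl carbon. Among the compounds with values here, no measured step covers an aromatic carbonyl substituent here, so the estimate rests on the flat step from compound 1 to compound 2. The step of a 1.0-fold lower number from compound 1 to compound 3 (0.02 log units; within the scatter) is therefore expected to stay within the scatter. Compound 3 is estimated at 7000 nM, ranging from 2500 nM to 20000 nM.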

Compound 3, half-maximal inhibitory concentration: 3690 nM
The estimate for compound 3 lay 1.9-fold (0.28 log units) above the measured number; the range from low to high includes it.
By their numbers in this assay, from the lowest: compounds 3, 1 and 2 (each within the scatter of the next, the first and the last beyond it).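

At this position on the ring amine nitrogen, the aromatic 3-(trifluoromethyl)phenyl on the carbonyl carbon gives a 2.0-fold lower number from compound 1 to compound 3 (0.30 log units; within the scatter) and so stays level with cyclohexyl. Set against the phenylsulfonyl group, the same acyl group gives a 2.1-fold lower number from compound 2 to compound 3 (0.32 log units; beyond the scatter) and so yields the first separation in the series, though a modest one. No evidence here bears on these steps.

As far as these compounds go, what remains open is whether the trifluoromethyl group or the aromatic ring itself matters. A plain phenyl on the carbonyl carbon, or an amine on that ring, would address this.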